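Chloro on the benzyl ring: compound 4 ahead of measurement

This account rests on a few compounds, and the source may have more. Where it says the series, first, only, none or still open, it means among the compounds named here.

Compound 1 `O/N=C(/Nc1cccc(F)c1)c1ccc2occc2c1` gives 32700 nM in an assay on isolated protein for inhibition of Indoleamine 2,3-dioxygenase 1 (Homo sapiens), read by spectrophotometry; a higher number here means a weaker inhibitor, a lower number a stronger inhibitor. Compound 2 `O/N=C(/Nc1ccc(Cl)c(F)c1)c1ccc2occc2c1` differs by chloro in place of hydrogen on an aromatic carbon. In this assay compound 2 gives > 30000 nM, a limit of the assay and not a number. The step that the limit leaves unreadable from compound 1 to compound 2 is thus unreadable in size, because of the limit of > 30000 nM in this assay, at which 2 of the 3 values shown sit. Compound 3 `O/N=C(/NCc1ccccc1)c1ccc2occc2c1` has another core; how the two cores differ is not broken down here. In this assay compound 3 gives > 30000 nM, again a limit. Compound 4 `O/N=C(/NCc1cccc(Cl)c1)c1ccc2occc2c1` differs from compound 3 by chloro in place of hydrogen on an aromatic carbon. This is the same kind of change as from compound 1 to compound 2, but the place differs: there ortho to a fluoro group and para to a large group, here meta to a large group. The step is expected to be a number no higher from compound 3 to compound 4 (the limit leaves the size open), because compound 3 gives > 30000 nM and nothing measured shows chloro moving potency. Compound 4 is expected at 30000 nM, between 12000 nM and 100000 nM.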

Compound 4, half-maximal inhibitory concentration: > 30000 nM
Compound 4 gave a limit, no number; the forecaster's own chance of this, stated with the estimate: 65%; the middle value lies on the limit itself.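

No step from compound 3 to compound 4 can be read, because both results are limits and not numbers: the limit of > 30000 nM in this assay, at which 3 of the 4 values shown sit.

Going by these compounds, whether 3-chlorophenyl in place of phenyl changes potency at all in this assay stays open.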